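This account rests on a few compounds, and the source may have more. Where it says the series, first, only, none or still open, it means among the compounds named here.

Values in a functional assay, with stated times of 30 s and 6 min, in the presence of a further agent that is not named here; a lower number here means a stronger inhibitor, a higher number a weaker inhibitor:
- compound 1 `CCCCCCCCOc1cc(OC)c(Br)cc1C(C)=O`: 30900000 nM
- compound 2 `CCCCCCCCCCOc1cc(OC)c(Br)cc1C(C)=O`: 15000000 nM
- compound 3 `CCCCCCCCCCCCOc1cc(OC)c(Br)cc1C(C)=O`: 10600000 nM

Compound 3 cannot be separated from its nearest neighbour in the series: a 1.4-fold lower number from compound 2 to compound 3 (0.15 log units; within the scatter). It does stand clear of the furthest one: a 2.9-fold lower number from compound 1 to compound 3 (0.46 log units; beyond the scatter).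

The next compound is compound 4 `CCCCCCCCCCCCCCOc1cc(OC)c(Br)cc1C(C)=O`, and the change is ethyl in place of hydrogen on a saturated chain carbon, ten or more bonds along the chain from an oxygen on an aromatic ring.

Two measured steps are the same kind of change. The closest match, at the same place on the chain, is a 1.4-fold lower number from compound 2 to compound 3 (0.15 log units; within the scatter). The other, eight bonds along the chain, is modest but beyond the scatter: a 2.1-fold lower number from compound 1 to compound 2 (0.31 log units; beyond the scatter). Both run towards a lower number, though three compounds make a thin basis for any trend. The closer match carries more weight, so a small further drop in this assay is expected, most likely not beyond the scatter.

The estimated step is a 1.2-fold lower number from compound 3 to compound 4 (0.10 log units; within the scatter). The estimate for compound 4 is 8500000 nM, with an expected range of 4500000 nM to 16000000 nM.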

Compound 4, half-maximal inhibitory concentration: 6800000 nM
For compound 4 the middle estimate is 1.3-fold (0.10 log units) above the measured one; the measured number falls inside the stated range.
By their numbers in this assay, from the lowest: compounds 4, 3 and 2 (each within the scatter of the next, the first and the last beyond it); then compound 1.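

In this assay, the further ethyl on the saturated chain carbon gives a step that cannot be separated from the scatter, a 1.6-fold lower number from compound 3 to compound 4 (0.19 log units; within the scatter), but the drift shows over longer spans, a 2.2-fold lower number from compound 2 to compound 4 (0.34 log units; beyond the scatter), and a 4.5-fold lower number from compound 1 to compound 4 (0.66 log units; beyond the scatter), while compound 4 still reads 6800000 nM. The ethyl change gives comparable steps at two points along the chain: the same change on two cores in this assay, a 2.1-fold lower number (0.31 log units; beyond the scatter) from compound 1 to compound 2 and a 1.6-fold lower number (0.19 log units; within the scatter) from compound 3 to compound 4, 1.3-fold (0.12 log units) apart, within the scatter of two such steps. The butyl change does the same over the longer spans: the same change on two cores in this assay, a 2.9-fold lower number (0.46 log units; beyond the scatter) from compound 1 to compound 3 and a 2.2-fold lower number (0.34 log units; beyond the scatter) from compound 2 to compound 4, 1.3-fold (0.12 log units) apart, within the scatter of two such steps.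

From the compounds shown here alone, whether a longer chain than that of compound 4 would carry this drift further or level it off remains open, as does the effect of an amine or a carboxylic acid on the chain in this assay. All four compounds share the core of compound 1, so these numbers do not show how far the chain steps would hold on another core.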